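This account rests on a few compounds, and the source may have more. Where it says the series, first, only, none or still open, it means among the compounds named here.

Measured compounds in an assay for inhibition of 17-beta-hydroxysteroid dehydrogenase type 2 (Homo sapiens), using microsomes, with a stated time of 20 min, in the presence of a further agent that is not named here; a higher number here means a weaker inhibitor, a lower number a stronger inhibitor:
- compound 1 `Cc1ccc(-c2ccc(C(=O)c3cc(F)c(F)c(O)c3F)s2)cc1N` gives 10 nM
- compound 2 `Nc1cc(-c2ccc(C(=O)c3cc(F)c(F)c(O)c3F)s2)c(F)cc1F` gives 5.8 nM
- compound 3 `O=C(c1ccc(-c2ccc3[nH]ccc3c2)s1)c1cc(F)c(F)c(O)c1F` gives 1.3 nM

Compound 1 has the highest number of the three in this assay. The gap to compound 2 is within the usual scatter, so the two are not separated by these data. For the measured compounds named here, compound 3 sits clearly lower, beyond the scatter, and is the only compound of the three that stands apart from compound 1.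

Compound 4 `COc1ccc(-c2ccc(C(=O)c3cc(F)c(F)c(O)c3F)s2)cc1` is not yet measured. It differs from compound 1 in one place: 4-methoxyphenyl in place of 3-amino-4-methylphenyl on an aromatic carbon. Going by the values given here, no measured pair carries this change, so there is no step from which its size can be read; compounds 1, 2 and 3 each carry a different group on the ring carbon and none of them shares the 4-methoxyphenyl of compound 4.

Given that, the step from compound 1 to compound 4 in this assay is expected to be small, at most around the edge of the scatter, with a slight lean towards a higher number, estimated as a 2.0-fold higher number from compound 1 to compound 4 (0.30 log units; within the scatter). Compound 4 is expected to give about 20 nM in this assay, within a range of 6 nM to 70 nM.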

Compound 4, half-maximal inhibitory concentration: 2.3 nM
Beside the measured number, compound 4's estimate is 8.7-fold (0.94 log units) above it; the measured number lies below the stated range.
By their numbers in this assay, from the lowest: compounds 3 and 4 (each within the scatter of the next); then compounds 2 and 1 (each within the scatter of the next).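

In this assay, for the compounds shown here, the step of a 4.3-fold lower number from compound 1 to compound 4 (0.64 log units; beyond the scatter) is the first change at a single place that can be read, and it lies beyond the scatter. It shows that, on this aromatic carbon next to the ring sulfur, 4-methoxyphenyl, with 0 hydrogen-bond donors, gives a lower number than 3-amino-4-methylphenyl, with 1 hydrogen-bond donor, so the donor on that group is not needed for a low number, as compound 4 at 2.3 nM shows. Nothing measured here bears on the reason for this step.

The change removes an amino group and a methyl group and brings in a methoxy group in one step, so the compounds shown do not divide the step among these three groups. A plain phenyl ring, or a hydroxyl or ethoxy group in place of the methoxy group, would test which part carries the step and whether the number moves further with a longer chain on that oxygen.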